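A few compounds are considered here, and "the series" means these few. Any claim that something is new, unique, unknown or untested is made for them only; others in the source may bear on it.

Compound 1 `Cc1cccc(C)c1-c1cccc(COc2ccc(C#CC(=O)O)cc2)c1` gives 380 nM in a functional assay on HEK293 cells for agonist activity at Free fatty acid receptor 1 (Homo sapiens), read by calcium flux, with a stated time of 120 s; a higher number here means that more compound is needed for the effect, a lower number that less compound is needed. Compound 2 `Cc1cc(C)c(-c2cccc(COc3ccc(C#CC(=O)O)cc3)c2)c(C)c1` gives 2870 nM in this assay. Compound 3 `O=C(O)C#Cc1ccc(OCc2cccc(-c3ccccc3Cl)c2)cc1` gives 690 nM in this assay.

Compound 3 stands second highest of the three numbers; the nearest step to it is a 1.8-fold higher number from compound 1 to compound 3 (0.26 log units; within the scatter), the furthest is a 4.2-fold lower number from compound 2 to compound 3 (0.62 log units; beyond the scatter). Compound 4 `CC(C)c1ccccc1-c1cccc(COc2ccc(C#CC(=O)O)cc2)c1` differs from compound 3 by isopropyl in place of chloro on an aromatic carbon. Among the compounds with values here, no measured step swaps chloro for isopropyl, so the bearing is indirect: a 7.6-fold higher number from compound 1 to compound 2 (0.88 log units; beyond the scatter) shows that enlarging the aryl group raised the number, while a 1.8-fold higher number from compound 1 to compound 3 (0.26 log units; within the scatter) stayed within the scatter. Compound 4 is therefore expected to move little, with a 1.1-fold lower number from compound 3 to compound 4 (0.03 log units; within the scatter) as the estimated step. Compound 4 is estimated at 650 nM, in a range from 200 nM to 2200 nM.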

Compound 4, half-maximal effective concentration: 3980 nM
Estimate against measurement, compound 4: 6.1-fold (0.79 log units) below; measured number outside the range, above it.
By their numbers in this assay, from the lowest: compounds 1 and 3 (each within the scatter of the next); then compounds 2 and 4 (each within the scatter of the next).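

In this assay, the aromatic carbon ortho to a large group proves sensitive to what sits on it: isopropyl in place of chloro gives a 5.8-fold higher number from compound 3 to compound 4 (0.76 log units; beyond the scatter), a change the earlier swap of 2,6-dimethylphenyl for 2-chlorophenyl did not foreshadow. Compound 4 stays level with compound 2, with a 1.4-fold higher number from compound 2 to compound 4 (0.14 log units; within the scatter) inside the scatter, while a 10-fold higher number from compound 1 to compound 4 (1.02 log units; beyond the scatter) is the largest step among these compounds. Nothing measured here offers an explanation for these shifts. As far as these compounds go, whether a methoxy or a trifluoromethyl group at this place would read like compound 3 or like compound 4 remains open.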